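The source may hold more compounds than are shown below. What is called first, only, known or untested is meant among the compounds shown, and "the series" means these compounds.

Working notes on the series. Compound 1 `Cc1cc(C(/C=C2\OC(=O)NC2=O)C(C)C)c(=O)[nH]c1-c1ccc2cccc(F)c2c1` and compound 2 `C/C(=C1/OC(=O)NC1=O)C(c1ccc(-c2ccc3cccc(F)c3c2)[nH]c1=O)C(C)C` share a core and have both been run in a functional assay on CHO cells for antagonist activity at prostaglandin E2 receptor EP3 subtype (Homo sapiens), read by cAMP accumulation, with a stated time of 30 min; a lower number here means a stronger inhibitor, a higher number a weaker inhibitor. In this assay compound 1 gives 92 nM, while compound 2 gives 39 nM; compound 1 thus stands with the higher of the two numbers, and the gap between them lies beyond the scatter. Compound 3 `CC(C)C(/C=C1\OC(=O)NC1=O)c1cc(Cl)c(-c2ccc3cccc(F)c3c2)[nH]c1=O` is not yet measured. It differs from compound 1 by chloro in place of methyl on an aromatic carbon. Among the compounds with values here, no measured pair shows this exchange, so no size of step is known; the expectation is a change of at most modest size, likely not beyond the scatter, as a 1.2-fold lower number from compound 1 to compound 3 (0.09 log units; within the scatter). Compound 3 is therefore estimated at 75 nM, with a range from 25 nM to 220 nM.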

Compound 3, half-maximal inhibitory concentration in the prostaglandin E2 receptor EP3 subtype assay: 360 nM
Compound 3: the middle estimate sits 4.8-fold (0.68 log units) below what was measured; the whole stated range lies below it.
By their numbers in the prostaglandin E2 receptor EP3 subtype assay, from the lowest: compound 2; then compound 1; then compound 3.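

At this aromatic carbon, ortho to a large group and two atoms from the ring nitrogen, the exchange of one heavy atom is not silent: in the prostaglandin E2 receptor EP3 subtype assay, compound 1 gives 92 nM and compound 3 gives 360 nM, so chloro in place of methyl gives a 3.9-fold higher number from compound 1 to compound 3 (0.59 log units; beyond the scatter), the first sign that activity depends on this position. In a physicochemical assay for solubility, in phosphate buffer, measured as kinetic solubility (a lower number here means a less soluble compound, a higher number a more soluble compound), compound 1 gives 35700 nM and compound 3 gives 21500 nM, so the same exchange gives a 1.7-fold lower number from compound 1 to compound 3 (0.22 log units; within the scatter), a smaller step. No evidence bearing on the size of this change is at hand. As far as these compounds go, whether a methoxy group, a nitrile or plain hydrogen at this carbon would match the methyl of compound 1 stays open. So does whether the exchange has the same effect on the core of compound 2.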